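The source may hold more compounds than are shown below. What is called first, only, known or untested is meant among the compounds shown, and "the series" means these compounds.

In a functional assay on the whole organism (arterial blood) with Rattus norvegicus as the target (on this read-out lower numbers stand for an effect already at smaller amounts and higher numbers for an effect only at larger amounts of compound), two compounds with a shared core have been measured. Compound 1 (`COc1ccccc1CCC(=O)N1CCC(Cn2c(C)nc3cnccc32)CC1`) gives 0.045 mg/kg, and compound 2 (`Cc1nc2cnccc2n1CC1CCN(C(=O)CC(C)(O)c2ccccc2)CC1`) gives 0.043 mg/kg. Among the measured compounds shown here, compound 2 therefore stands level with its only neighbour on the numbers, as a 1.0-fold lower number from compound 1 to compound 2 (0.02 log units; within the scatter) shows. That step replaced 2-methoxybenzyl with 1-hydroxy-1-phenylethyl on a saturated chain carbon bound to a carbonyl carbon.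

The unmeasured compound 3 (`COc1ccccc1N(C)CC(=O)N1CCC(Cn2c(C)nc3cnccc32)CC1`) differs from compound 2 at that same place: (2-methoxyphenyl)(methyl)amino in place of 1-hydroxy-1-phenylethyl on a saturated chain carbon bound to a carbonyl carbon. Here, (2-methoxyphenyl)(methyl)amino replaces 1-hydroxy-1-phenylethyl. For the measured compounds named here, the one measured step bearing on this change is small, and it is the only evidence, so the range is kept wide. No shift beyond the scatter is expected in this assay. The expected change is a 1.2-fold higher number from compound 2 to compound 3 (0.07 log units; within the scatter). For compound 3 the estimate is 0.05 mg/kg, with an expected range of 0.015 mg/kg to 0.17 mg/kg.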

Compound 3, dose for 50% inhibition: 0.063 mg/kg
Beside the measured number, compound 3's estimate is 1.3-fold (0.10 log units) below it, and the stated range covers the measured number.
By their numbers in this assay, from the lowest: compounds 2, 1 and 3 (each within the scatter of the next).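

In this assay, a third group at this place on a saturated chain carbon bound to a carbonyl carbon leaves the number within the scatter: the change is a 1.5-fold higher number from compound 2 to compound 3 (0.17 log units; within the scatter) against 1-hydroxy-1-phenylethyl and a 1.4-fold higher number from compound 1 to compound 3 (0.15 log units; within the scatter) against 2-methoxybenzyl. The entering (2-methoxyphenyl)(methyl)amino group carries a nitrogen atom that neither earlier group has, and the numbers of all three compounds still lie within the scatter of each other. No measurement at hand gives a reason for this.

All three groups contain a six-membered aromatic ring of carbon only, so the compounds shown leave open whether a group without that ring, such as a simple amine or a carboxylic acid, would keep the number at this level. From the compounds shown here alone, whether a longer chain would do so also stays open.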